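Phenyl in place of propyl: expected whole-organism potency

The compounds below may be only part of what the source reports. "The series", "measured", "known", "first", "only" and "open" are said of these compounds alone.

Compound 1 `CCCCN1CCC(C(=O)Nc2cc(Cl)c(N)cc2OC)CC1`: > 10 mg/kg
Compound 2 `COc1cc(N)c(Cl)cc1NC(=O)C1CCN(CC2CCCCC2)CC1`: 2.9 mg/kg

In a functional assay on the whole organism for antagonist activity, with Mus musculus as the target (a lower number here means that less compound is needed, a higher number that more compound is needed for the effect), compound 1 gives only a limit, > 10 mg/kg, so it sits at the limit of > 10 mg/kg in this assay, at which 1 of the 2 values shown sits. Among the measured compounds shown here, compound 2 gives 2.9 mg/kg, and the one measured step, an at least 3.4-fold lower number from compound 1 to compound 2 (0.53 log units; beyond the scatter), is the only guide for the change at hand. Compound 3 `COc1cc(N)c(Cl)cc1NC(=O)C1CCN(Cc2ccccc2)CC1` differs from compound 1 by phenyl in place of propyl on a saturated chain carbon bound to an amine nitrogen in a ring, a change at the same place as the measured step. A lowering beyond the scatter is therefore expected, an at least 2.8-fold lower number from compound 1 to compound 3 (0.45 log units; beyond the scatter). Compound 3 is estimated at 3.5 mg/kg, with a range from 1.2 mg/kg to 10 mg/kg.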

Compound 3, dose for half-maximal effect: 0.5 mg/kg
Compound 3: middle estimate off by 7.0-fold (0.85 log units), on the high side, and the stated range ends above it.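

At this place, on a saturated chain carbon bound to an amine nitrogen in a ring, the kind of ring matters: phenyl in place of cyclohexyl gives a 5.8-fold lower number from compound 2 to compound 3 (0.76 log units; beyond the scatter) in this assay and so separates two ring-bearing compounds. Compound 1 has only a limit, so an at least 20-fold lower number from compound 1 to compound 3 (1.30 log units; beyond the scatter) fixes a bound and not a full size: (the limit of > 10 mg/kg in this assay, at which 1 of the 3 values shown sits).

The compounds shown leave open whether phenyl itself is required or whether a pyridyl ring would serve at this place. As far as these compounds go, the effect of a substituent on the phenyl, such as chloro or methoxy, also remains open.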